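The compounds below may be only part of what the source reports. "The series", "measured", "known", "first", "only" and "open" are said of these compounds alone.

Compound 1 `Cc1nc(SCC(=O)Nc2nc(-c3ccc(Cl)cc3)cs2)n(Nc2ccccc2)c1C`: 31700 nM.
Compound 2 `Cc1ccc(Nn2c(SCC(=O)Nc3nc(-c4ccccc4)cs3)nc(C)c2C)cc1`: > 100000 nM.

Within the data shown here, in a functional assay on HOP-62 cells (Homo sapiens) for antiproliferative activity, read by sulforhodamine B assay, with a stated time of 48 h (a higher number here means that more compound is tolerated, a lower number that less compound is tolerated), compound 1 gives 31700 nM, the only number. For compound 2 this assay reports only a limit, > 100000 nM, so the limit of > 100000 nM in this assay, at which 1 of the 2 values shown sits, is where one of the two values sits. Compound 3 `COc1ccc(Nn2c(SCC(=O)Nc3nc(-c4ccc(Cl)cc4)cs3)nc(C)c2C)cc1` differs from compound 1 by methoxy in place of hydrogen on an aromatic carbon, a methoxy in place of hydrogen on an aromatic carbon of a six-membered aromatic ring of carbon only. Among the measured compounds shown here, no measured step shows what this substitution does here, so the expected step of a 1.6-fold higher number from compound 1 to compound 3 (0.20 log units; within the scatter) is modest, toward more compound being tolerated, and not clearly beyond the scatter. Compound 3 is estimated at 50000 nM, between 18000 nM and 140000 nM.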

Compound 3, concentration lethal to 50% of the cells: > 100000 nM
Compound 3 gave a limit, no number; the forecaster's own chance of this, stated with the estimate: 35%; at least 2.0-fold (0.30 log units) between middle value and limit.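

Among these compounds, the first measured step at this position comes from the change of phenyl to 4-methoxyphenyl, which gives an at least 3.1-fold higher number from compound 1 to compound 3 (0.49 log units; beyond the scatter) in this assay. On this core, then, methoxy in place of hydrogen on this aromatic carbon moves the number beyond the scatter, toward more compound being tolerated. Compound 3 stands at a limit and not at a number, so the step gives only a lower bound on the size of the change: the limit of > 100000 nM in this assay, at which 2 of the 3 values shown sit.

The compounds shown leave open whether fluorine, a hydroxyl or an amine at this place would keep a measurable number in this assay.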